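A few compounds are considered here, and "the series" means these few. Any claim that something is new, unique, unknown or untested is made for them only; others in the source may bear on it.

Of the compounds shown here, two have been measured in an assay on HEK293 cells for displacement of a labelled ligand from growth hormone secretagogue receptor type 1 (Homo sapiens), with a stated time of 60 min; a lower number here means a stronger inhibitor, a higher number a weaker inhibitor. Compound 1 `CN1CCN(CCCS(=O)(=O)c2ccc3nc(NC(=O)NC(=O)c4cc(C5CC5)ccc4Cl)sc3c2)CC1` gives 0.33 nM, the lowest of the two numbers. Compound 2 `COCCNCCCS(=O)(=O)c1ccc2nc(NC(=O)NC(=O)c3ccccc3Cl)sc2c1` differs from compound 1 in several places at once; in this assay compound 2 gives 8.6 nM, a higher number that lies well beyond the usual scatter of repeated measurements, so compound 1 is the stronger binder of the pair.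

Compound 3 `CCOc1ccc(Cl)c(C(=O)NC(=O)Nc2nc3ccc(S(=O)(=O)CCCN4CCN(C)CC4)cc3s2)c1` has not yet been measured. It differs from compound 1 in a single place: ethoxy in place of cyclopropyl on an aromatic carbon. Among the compounds with values here, no measured pair shows this particular exchange, so no direct guide exists, and the outcome can only be estimated from the fact that the rest of the molecule is unchanged and the two groups are of like size in the comparison. The step of a 2.4-fold higher number from compound 1 to compound 3 (0.38 log units; beyond the scatter) is expected to be small, a slight loss of binding within or just beyond the scatter. Compound 3 is therefore expected to give about 0.8 nM, with a likely range from 0.25 nM to 3 nM.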

Compound 3, half-maximal inhibitory concentration: 0.31 nM
Compound 3: the middle estimate sits 2.6-fold (0.41 log units) above what was measured; the measured number falls inside the stated range.
By their numbers in this assay, from the lowest: compounds 3 and 1 (each within the scatter of the next); then compound 2.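

In this assay the exchange of cyclopropyl for ethoxy on this aromatic carbon, para to the chloro group, gives a 1.1-fold lower number from compound 1 to compound 3 (0.03 log units; within the scatter) and so leaves the two compounds indistinguishable. The earlier pair could not isolate this position, as compound 2 differs from compound 1 in several places at once; here, a carbon-only ring gives way to an open chain with an oxygen and one hydrogen-bond acceptor, at the same count of heavy atoms, without a change beyond the scatter. No evidence is available to explain why the exchange is tolerated.

As far as these compounds go, it remains open whether this position would accept a longer chain such as butoxy, or a different kind of group such as an amine or a carboxylic acid. From the compounds shown here alone, it is also open whether the same exchange would give a similar result on the rest of compound 2.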